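Solubility notes: ethylcarbamoyl swapped for (dimethylamino)methyl

This account rests on a few compounds, and the source may have more. Where it says the series, first, only, none or still open, it means among the compounds named here.

Among the measured compounds shown here, compound 2 `CCNC(=O)c1cc(N)c(Nc2ccc(C#N)cc2)cc1Oc1c(C)cc(CCC#N)cc1C` is one of two compounds measured so far in a physicochemical assay for solubility, read by HPLC, with a stated time of 4 h, at pH 2, tested at 10 mg/mL (on this read-out lower numbers stand for lower solubility and higher numbers for higher solubility), where compound 2 gives 69.4 ug/mL. For the measured compounds named here, its only neighbour is compound 1 `Cc1cc(CCC#N)cc(C)c1Oc1cc(Nc2ccc(C#N)cc2)c(N)cc1C(=O)N(C)C`, which in this assay gives 65.1 ug/mL; the step of a 1.1-fold higher number from compound 1 to compound 2 (0.03 log units; within the scatter) is within the scatter, so the two numbers cannot be told apart. Compound 3 `Cc1cc(CCC#N)cc(C)c1Oc1cc(Nc2ccc(C#N)cc2)c(N)cc1CN(C)C` has not yet been measured. It differs from compound 2 by (dimethylamino)methyl in place of ethylcarbamoyl on an aromatic carbon. Going by the values given here, the single measured step, a 1.1-fold higher number from compound 1 to compound 2 (0.03 log units; within the scatter), touched the same group but only on its carbonyl carbon and gave no shift beyond the scatter; no measured step removes the carbonyl itself, so there is no direct precedent for this change. The expected step of a 1.7-fold higher number from compound 2 to compound 3 (0.24 log units; within the scatter) is therefore set close to no change, with a wide range to cover the lack of precedent. For compound 3 the estimate in this assay is 120 ug/mL, with a range from 40 ug/mL to 600 ug/mL.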

Compound 3, solubility: 260 ug/mL
Compound 3: middle estimate off by 2.2-fold (0.34 log units), on the low side; the measured number falls inside the stated range.
By their numbers in this assay, from the lowest: compounds 1 and 2 (each within the scatter of the next); then compound 3.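

At this aromatic carbon, para to the (4-cyanophenyl)amino group, the group does matter in this assay: (dimethylamino)methyl in place of ethylcarbamoyl gives a 3.7-fold higher number from compound 2 to compound 3 (0.57 log units; beyond the scatter), and in place of dimethylcarbamoyl it gives a 4.0-fold higher number from compound 1 to compound 3 (0.60 log units; beyond the scatter). The earlier step, a 1.1-fold higher number from compound 1 to compound 2 (0.03 log units; within the scatter), changed only what sits on the carbonyl carbon, whereas these two steps, both beyond the scatter, replace the whole carbamoyl group, carbonyl included. Nothing at hand bears on why the number rises.

Still open, from the compounds shown here alone, is whether the rise goes with the amine in the new group or simply with the departure of the carbonyl, and a hydroxymethyl or plain methyl at this carbon would separate the two. Also open, going by these compounds, is how far the rise carries over to a longer chain before the nitrogen or to a morpholinomethyl group.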